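Moving the Methoxy Group on a Second Core in HeLa Cells

This account rests on a few compounds, and the source may have more. Where it says the series, first, only, none or still open, it means among the compounds named here.

Measured compounds:
compound 1 `C=C(Br)C(=O)Nc1ccc(/C=C/C(=O)c2ccc(OC)cc2)cc1` — 1400 nM
compound 2 `C=C(Br)C(=O)Nc1ccc(/C=C/C(=O)c2cccc(OC)c2)cc1` — 700 nM
compound 3 `C=C(Br)C(=O)Nc1ccc(C(=O)/C=C/c2ccc(OC)cc2)cc1` — 310 nM

All three were tested in a functional assay on HeLa cells (Homo sapiens) for antiproliferative activity, with a stated time of 48 h; on this read-out higher numbers stand for weaker inhibition and lower numbers for stronger inhibition. Compound 2 differs from compound 1 by 3-methoxyphenyl in place of 4-methoxyphenyl on a carbonyl carbon, and this change gave a 2.0-fold lower number from compound 1 to compound 2 (0.30 log units; within the scatter). Compound 3 gives the lowest of the three numbers; the difference between its core and that of compound 1 is not broken down here.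

Compound 4 `C=C(Br)C(=O)Nc1ccc(C(=O)/C=C/c2cccc(OC)c2)cc1` has not yet been measured in this assay. It differs from compound 3 by 3-methoxyphenyl in place of 4-methoxyphenyl on a double-bonded chain carbon bound to a double-bonded chain carbon. This is the same kind of change as that from compound 1 to compound 2 but not the same one: there the group sits on a carbonyl carbon, here on a double-bonded chain carbon bound to a double-bonded chain carbon. Because the earlier move gave only a 2.0-fold lower number from compound 1 to compound 2 (0.30 log units; within the scatter), a step of similar size, a 1.6-fold lower number from compound 3 to compound 4 (0.19 log units; within the scatter), is expected. Compound 4 is therefore estimated at 200 nM, with a likely range from 80 nM to 600 nM.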

Compound 4, half-maximal inhibitory concentration: 500 nM
Compound 4: the middle estimate sits 2.5-fold (0.40 log units) below what was measured; measured number inside the range.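

In this assay, 3-methoxyphenyl in place of 4-methoxyphenyl on a double-bonded chain carbon bound to a double-bonded chain carbon gave a 1.6-fold higher number from compound 3 to compound 4 (0.21 log units; within the scatter). Set beside the earlier step, the change does not carry over unchanged from one core to the other: the same change on two cores in this assay, a 2.0-fold lower number (0.30 log units; within the scatter) from compound 1 to compound 2 and a 1.6-fold higher number (0.21 log units; within the scatter) from compound 3 to compound 4, 3.2-fold (0.51 log units) apart, beyond the scatter of two such steps. For the compounds shown here, each step lies within the scatter by itself and each core supplies only one pair; the comparison shows that the two steps differ, but not why, nor how the change would behave on any further core.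

The compounds shown leave open how a hydroxyl group or an ethoxy group in place of the methoxy group would behave on either core. They also leave open whether an unsubstituted phenyl ring would show the same gap between the two cores.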